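The compounds below may be only part of what the source reports. "The series", "measured", "known", "first", "only" and "open" are said of these compounds alone.

Working notes on the series. Compound 1 `O=C(O)c1ccccc1-c1ccc(CCc2ncc(CC3CCC3)[nH]2)cc1` is the reference point; in an in vitro functional assay on cells for agonist activity at Bombesin receptor subtype-3 (Homo sapiens), read by luminescence and calcium flux (a lower number here means that less compound is needed, a higher number that more compound is needed for the effect), compound 1 gives 588 nM, the lowest of the three numbers at hand. Compound 2 `Cc1cccc(Cc2cnc(CCc3ccc(-c4ccccc4C(=O)O)cc3)[nH]2)c1` gives 4310 nM in this assay, and compound 3 `N#Cc1ccccc1Cc1cnc(CCc2ccc(-c3ccccc3C(=O)O)cc2)[nH]1` gives 5480 nM. Both replacements of the cyclobutyl by an aryl group moved the number the same way: a 7.3-fold higher number from compound 1 to compound 2 (0.87 log units; beyond the scatter) and a 9.3-fold higher number from compound 1 to compound 3 (0.97 log units; beyond the scatter). Between the two aryl compounds themselves the gap is small, a 1.3-fold higher number from compound 2 to compound 3 (0.10 log units; within the scatter), so which aryl group was present did not matter beyond the scatter in this pair.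

Compound 4 `N#Cc1cccc(Cc2cnc(CCc3ccc(-c4ccccc4C(=O)O)cc3)[nH]2)c1` differs from compound 1 in one place: 3-cyanophenyl in place of cyclobutyl on a saturated chain carbon bound to an aromatic carbon. The two measured steps from compound 1, to 3-methylphenyl and to 2-cyanophenyl, both bear on this change; both were modest, beyond the scatter, and toward a higher number, and the nitrile-bearing aryl compound did not separate from the methyl-bearing one. A step of similar size, toward a higher number, is therefore expected: an 8.5-fold higher number from compound 1 to compound 4 (0.93 log units; beyond the scatter). For compound 4 the estimate in this assay is 5000 nM, with a range from 2000 nM to 13000 nM.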

Compound 4, half-maximal effective concentration: 812 nM
Compound 4: the middle estimate sits 6.2-fold (0.79 log units) above what was measured, and the stated range ends above it.
By their numbers in this assay, from the lowest: compounds 1 and 4 (each within the scatter of the next); then compounds 2 and 3 (each within the scatter of the next).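

Compound 4 shows that putting an aryl group on this saturated chain carbon does not by itself go with a higher number: a 1.4-fold higher number from compound 1 to compound 4 (0.14 log units; within the scatter), so 3-cyanophenyl and cyclobutyl cannot be told apart here, and compound 4 goes against the trend seen with compounds 2 and 3. The aryl substitution turns out to matter at this position, which the earlier gap between compounds 2 and 3 did not reveal: moving the nitrile gives a 6.7-fold lower number from compound 3 to compound 4 (0.83 log units; beyond the scatter), and exchanging methyl for cyano on the same aromatic carbon gives a 5.3-fold lower number from compound 2 to compound 4 (0.72 log units; beyond the scatter). No supporting measurement on hand bears on what lies behind these differences.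

The compounds shown leave open whether an unsubstituted phenyl, or a phenyl carrying a methoxy or trifluoromethyl group in place of the nitrile, would also stay within the scatter of compound 1 in this assay. They also leave open whether a pyridyl ring in place of the 3-cyanophenyl would keep the number of compound 4 or move towards those of compounds 2 and 3.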